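Swapping a Benzyl Arm for Allyl on a Shared Core

The source may hold more compounds than are shown below. What is called first, only, known or untested is meant among the compounds shown, and "the series" means these compounds.

Compound 1, `Cc1cc(N2CC[C@@H](C)[C@@H](N(C)c3ncnc4[nH]ccc34)C2)n2nc(SCc3ccc(C(F)(F)F)cc3)nc2n1`, was tested in a functional assay on BGC-823 cells (Homo sapiens) for inhibition, read by MTT assay, with a stated time of 72 h (a lower number here means a stronger inhibitor, a higher number a weaker inhibitor), and gave 23300 nM, the lower of the two numbers at hand. Compound 2, `CCc1cc(N2CC[C@@H](C)[C@@H](N(C)c3ncnc4[nH]ccc34)C2)n2ncnc2n1`, gave 82200 nM in this assay, a weaker result that lies beyond the scatter. Compound 3, `C=CCSc1nc2nc(C)cc(N3CC[C@@H](C)[C@@H](N(C)c4ncnc5[nH]ccc45)C3)n2n1`, has not been measured; it differs from compound 1 by vinyl in place of 4-(trifluoromethyl)phenyl on a saturated chain carbon bound to a sulfur. Among the measured compounds shown here, no measured pair shows what such a change does here, so the size of the step is open. The step of a 1.7-fold higher number from compound 1 to compound 3 (0.23 log units; within the scatter) is expected to be modest, toward a weaker inhibitor, possibly within the scatter. Compound 3 is estimated at 40000 nM, between 12000 nM and 130000 nM.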

Compound 3, half-maximal inhibitory concentration: 40900 nM
Compound 3: the middle estimate sits 1.0-fold (0.01 log units) below what was measured; the measured number falls inside the stated range.
By their numbers in this assay, from the lowest: compounds 1, 3 and 2 (each within the scatter of the next, the first and the last beyond it).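

In this assay replacing 4-(trifluoromethyl)phenyl with vinyl on a saturated chain carbon bound to a sulfur gives a 1.8-fold higher number from compound 1 to compound 3 (0.24 log units; within the scatter) as the size of the change. At this position, then, a group of 10 heavy atoms with an aromatic ring can give way to one of 2 heavy atoms with no ring without a change that stands out from the scatter. Nothing measured here explains this result.

As far as these compounds go, whether an amine, a carboxylic acid or a longer chain at this place would shift the number beyond the scatter remains open.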